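Hydroxycyclobutylmethyl in Place of Hydroxyoxanyl on the Amide

A few compounds are considered here, and "the series" means these few. Any claim that something is new, unique, unknown or untested is made for them only; others in the source may bear on it.

Measured compounds:
compound 1 `O=C(N[C@H]1CCOC[C@@H]1O)c1cn(Cc2ccc(-n3cccn3)cc2)c2cccnc12`: < 8 mL/min/kg
compound 2 `O=C(N[C@H]1CCCC[C@@H]1O)c1nn(Cc2ccc(-n3cccn3)cc2)c2cccnc12`: 9.6 mL/min/kg
compound 3 `O=C(N[C@H]1CCOC[C@@H]1O)c1cn(Cc2ccc(-c3cc[nH]n3)cc2)c2cccnc12`: 9.2 mL/min/kg

The three compounds were run in an ADME assay on liver for metabolic stability, with Liver microsome (Homo sapiens) as the target, using microsomes; a lower number here means slower removal, a higher number faster removal of the compound. For compound 1 the reading is a limit of the assay and not a number. Compound 1 therefore sits at the limit of < 8 mL/min/kg in this assay, at which 1 of the 3 values shown sits, and its place among the numbers shown is known only as a range.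

Compound 4 `O=C(NCC1(O)CCC1)c1cn(Cc2ccc(-n3cccn3)cc2)c2cccnc12` has not yet been measured. It differs from compound 1 by (1-hydroxycyclobutyl)methyl in place of 3-hydroxyoxan-4-yl on an amide-type nitrogen. Among the measured compounds shown here, the only single-point step measured so far is an at least 1.1-fold higher number from compound 1 to compound 3 (0.06 log units; that floor lies within the scatter), which concerns the pyrazolyl group on the aromatic carbon, not the amide substituent, and lies within the scatter. Compound 2 and compound 1 differ in more than one place, so their values can only be set side by side. For the measured compounds named here, no measured step bears on the amide change itself.

Accordingly, no step beyond the scatter is expected, a number no lower from compound 1 to compound 4 (the limit leaves the size open). Compound 4 is estimated at 8 mL/min/kg, with a range from 4 mL/min/kg to 16 mL/min/kg.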

Compound 4, clearance: 17 mL/min/kg
Estimate against measurement, compound 4: 2.1-fold (0.33 log units) below; the whole stated range lies below it.
By their numbers in this assay, from the lowest: compounds 3, 2 and 4 (each within the scatter of the next). At a limit, below all of these: compound 1.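

The amide-type nitrogen turns out to be a place where this assay responds to a change: (1-hydroxycyclobutyl)methyl in place of 3-hydroxyoxan-4-yl gives an at least 2.1-fold higher number from compound 1 to compound 4 (0.32 log units; beyond the scatter). This step lies beyond the scatter, whereas the floor of the earlier step on the pyrazolyl group, an at least 1.1-fold higher number from compound 1 to compound 3 (0.06 log units; that floor lies within the scatter), lies within it. Compound 1 stands at a limit of the assay, which leaves the full size of the new step open: the limit of < 8 mL/min/kg in this assay, at which 1 of the 4 values shown sits.

The exchange alters the ring, its hetero atom and the defined stereocentres together, so the compounds shown do not tell which of these parts carries the step. They also leave open how a carboxylic acid or a longer hydroxyalkyl chain on this amide-type nitrogen would read in this assay.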